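Dihalo chalcone series: methoxy to fluoro on the aroyl ring

A few compounds are considered here, and "the series" means these few. Any claim that something is new, unique, unknown or untested is made for them only; others in the source may bear on it.

Compound 1 `COc1ccc(C(=O)/C=C/c2cc(Br)cc(Br)c2Oc2c([N+](=O)[O-])cc(C(F)(F)F)cc2[N+](=O)[O-])cc1` and compound 2 `COc1ccc(C(=O)/C=C/c2cc(Cl)cc(Cl)c2Oc2c([N+](=O)[O-])cc(C(F)(F)F)cc2[N+](=O)[O-])cc1` are built on a shared core; the difference between the two cores is not broken down here. In a functional assay on MCF7 cells (Homo sapiens) for antiproliferative activity, read by MTT assay, with a stated time of 48 h (on this read-out lower numbers stand for stronger inhibition and higher numbers for weaker inhibition), compound 1 gives 3.53 ug/mL, and compound 2 gives 2.69 ug/mL, the two lying within the scatter of each other. Compound 3 `O=C(/C=C/c1cc(Br)cc(Br)c1Oc1c([N+](=O)[O-])cc(C(F)(F)F)cc1[N+](=O)[O-])c1ccc(F)cc1` carries the change fluoro in place of methoxy on an aromatic carbon relative to compound 1. In this assay compound 3 gives 8.06 ug/mL, a step of a 2.3-fold higher number from compound 1 to compound 3 (0.36 log units; beyond the scatter). Compound 4 `O=C(/C=C/c1cc(Cl)cc(Cl)c1Oc1c([N+](=O)[O-])cc(C(F)(F)F)cc1[N+](=O)[O-])c1ccc(F)cc1` is not yet measured; it carries the change fluoro in place of methoxy on an aromatic carbon relative to compound 2, the same kind of change at a place described in the same words. Within the data shown here, the expected step is a 2.3-fold higher number from compound 2 to compound 4 (0.36 log units; beyond the scatter), similar in size because a 2.3-fold higher number from compound 1 to compound 3 (0.36 log units; beyond the scatter) is the only measured instance of this change. Compound 4 is therefore estimated at 6.2 ug/mL in this assay, with a range from 3.5 ug/mL to 11 ug/mL.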

Compound 4, half-maximal inhibitory concentration: 5.02 ug/mL
Compound 4: middle estimate off by 1.2-fold (0.09 log units), on the high side; measured number inside the range.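

In this assay, fluoro in place of methoxy on an aromatic carbon gives a 1.9-fold higher number from compound 2 to compound 4 (0.27 log units; within the scatter). The change therefore carries from the core of compound 1 to the core of compound 2 with no difference in step size that can be told from scatter: the same change on two cores in this assay, a 2.3-fold higher number (0.36 log units; beyond the scatter) from compound 1 to compound 3 and a 1.9-fold higher number (0.27 log units; within the scatter) from compound 2 to compound 4, 1.2-fold (0.09 log units) apart, within the scatter of two such steps. Among these compounds, this rests on only two cores in one assay, and only the step on the core of compound 1 lies beyond the scatter, so it does not show that the step would hold on other cores.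

The compounds shown leave open how an amine, a carboxylic acid or a longer chain such as ethoxy would read at this place, para to a large group. They also leave open whether the hydrogen-only phenyl ring would fall nearer the 4-methoxyphenyl or the 4-fluorophenyl compounds.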